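The compounds below may be only part of what the source reports. "The series", "measured", "known", "first", "only" and "open" are said of these compounds alone.

Working notes on the series, all read in a physicochemical assay for solubility, read by spectrophotometry, in phosphate buffer, with a stated time of 2 h, at pH 7.4; a higher number here means a more soluble compound, a lower number a less soluble compound. Compound 1 `COc1ccc2[nH]c(C(=O)N3CC(=O)N(Cc4ccccc4)[C@@H](CN4CCC5(CC4)CC5)C3)cc2c1` gives 28200 nM. Among the compounds with values here, compound 2 `COc1ccc2[nH]c(C(=O)N3CC(=O)N(Cc4ccccc4)[C@@H](CN4CCN(c5ccccn5)CC4)C3)cc2c1` gives 30200 nM, which leaves it level with compound 1 within the scatter, and these are the only two numbers so far. Compound 3 `COc1ccc2[nH]c(C(=O)N3CC(=O)N(Cc4ccccc4)[C@@H](CN4CC5CC5C4)C3)cc2c1` keeps the shared core and differs from compound 2 in one place: a group of 6 heavy atoms (5 carbon, 1 nitrogen; one three-membered non-aromatic ring of carbon only, one five-membered non-aromatic ring with 1 hetero atom) in place of a group of 12 heavy atoms (9 carbon, 3 nitrogen; one six-membered non-aromatic ring with 2 hetero atoms, one six-membered aromatic ring with 1 hetero atom), on a saturated chain carbon bound to a saturated ring carbon. The 4-(pyridin-2-yl)piperazin-1-yl group therefore leaves, and a group with a three-membered non-aromatic ring of carbon only and a five-membered non-aromatic ring enters. Within the data shown here, one measured step bears on this, the exchange at the same place that links compound 2 to compound 1: a 1.1-fold higher number from compound 1 to compound 2 (0.03 log units; within the scatter). No step beyond the scatter is expected for compound 3 because a 1.1-fold higher number from compound 1 to compound 2 (0.03 log units; within the scatter) stayed small, although that is a single step and neither measured compound carries the entering group. The expected size of the change is a 1.0-fold lower number from compound 2 to compound 3 (0.00 log units; within the scatter), with no direction favoured. In this assay compound 3 is expected at 30000 nM, with an estimated range from 14000 nM to 60000 nM.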

Compound 3, solubility: 17500 nM
Beside the measured number, compound 3's estimate is 1.7-fold (0.23 log units) above it; low and high end bracket the measured number.
By their numbers in this assay, from the lowest: compounds 3, 1 and 2 (each within the scatter of the next).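

With three groups now read on a saturated chain carbon bound to a saturated ring carbon, this assay still shows no step beyond the scatter at this place: a 1.7-fold lower number from compound 2 to compound 3 (0.24 log units; within the scatter), and a 1.6-fold lower number from compound 1 to compound 3 (0.21 log units; within the scatter). The group of 6 heavy atoms therefore stands level with both the 4-(pyridin-2-yl)piperazin-1-yl group of 12 heavy atoms and the group of 8 heavy atoms, so for these three compounds the read-out does not separate groups of these sizes, and the exchange of a six-membered non-aromatic ring for a five-membered one, with the three-membered carbon ring present in both, also stays within the scatter. Nothing in the data at hand accounts for where the three numbers sit.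

Open, on these data alone, is whether any group at this place gives a step beyond the scatter, for example a morpholine, a carboxylic acid or an open dimethylamino chain. Also open is whether the level readings among these three groups hold once the shared core is changed elsewhere.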